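The compounds below may be only part of what the source reports. "The series", "measured", "known", "first", "only" and "open" are said of these compounds alone.

Among the three measured compounds, compound 1 `Cc1cc2c(c(=O)[nH]1)OC(C(=O)CC(C)C)O2` stands at the top of the numbers in a functional assay on HL-60 cells (Homo sapiens) for cytotoxicity, read by WST assay, with a stated time of 48 h; a lower number here means a stronger inhibitor, a higher number a weaker inhibitor: compound 1 gives 19900 nM. Among the measured compounds shown here, compound 2 `CC1=CC(=O)[C@]2(O[C@@H]2C(=O)CC(C)C)C(=O)N1` gives 1700 nM, and compound 3 `CC1=CC(=O)C2(OC2C(=O)CC(C)C)C(=O)N1` gives 1800 nM; the only single-point step in the set, a 1.1-fold higher number from compound 2 to compound 3 (0.02 log units; within the scatter), is what one would expect because the fact that one of compounds 2 and 3 is drawn with a defined configuration and the other without, at the place where they differ is all that separates them. Both compounds sit well beyond the scatter from compound 1, which is therefore the weakest inhibitor of the three in this assay.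

Compound 4 `CC(C)CC(=O)C1Oc2cc(Cc3ccccc3)[nH]c(=O)c2O1` differs from compound 1 by phenyl in place of hydrogen on a saturated chain carbon bound to an aromatic carbon. For the measured compounds named here, no measured step speaks to this change: the one step in the set, a 1.1-fold higher number from compound 2 to compound 3 (0.02 log units; within the scatter), concerns drawn configuration only, and the gap between compound 1 and compounds 2 and 3 is not a single-place step. With nothing in the data to anchor a shift, the step of a 1.3-fold lower number from compound 1 to compound 4 (0.12 log units; within the scatter) is expected to stay within the scatter. Compound 4 is thus estimated at 15000 nM, with a range from 5000 nM to 50000 nM.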

Compound 4, half-maximal inhibitory concentration: > 50000 nM
Compound 4 was reported as a limit; the forecaster's own chance of this, stated with the estimate: 10%; middle value at least 3.3-fold (0.52 log units) from the limit.
By their numbers in this assay, from the lowest: compounds 2 and 3 (each within the scatter of the next); then compound 1. At a limit, above all of these: compound 4.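

Among the compounds shown here, on the saturated chain carbon bound to an aromatic carbon, phenyl in place of hydrogen (methyl to benzyl, cut one bond further out) gives the first single-place step in the set that lies beyond the scatter: an at least 2.5-fold higher number from compound 1 to compound 4 (0.40 log units; beyond the scatter). In this assay compound 4 is reported only as a limit, > 50000 nM. This change at this position therefore costs activity in this assay, but the full size of the loss cannot be read: the limit of > 50000 nM in this assay, at which 1 of the 4 values shown sits.

The compounds shown carry only methyl and benzyl at this place, so it remains open how a longer chain such as propyl, or a benzyl bearing an amine, would read. From the compounds shown here alone, it is also open whether the same change on the core of compound 2 would move the number in the same way.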